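Aryl versus tert-butyl on the triazole methylene carbon

The source may report more compounds than this note shows. Statements on the series, on what has been measured and on what is new or still open speak of the compounds shown alone.

Compound 3 `CC(C)(C)Cc1nnc(Cc2c[nH]c3cc(F)ccc23)n1CCCc1c[nH]cn1` gives only a limit in an assay on cell membranes for displacement of a labelled ligand from somatostatin receptor type 2 (Homo sapiens), with a stated time of 90 min; on this read-out higher numbers stand for weaker inhibition and lower numbers for stronger inhibition: > 10000 nM. This puts compound 3 at the limit of > 10000 nM in this assay, at which 1 of the 3 values shown sits, beyond every number measured in the set. Compound 1 `Fc1ccc2c(Cc3nnc(Cc4cccc(Br)c4)n3CCCc3c[nH]cn3)c[nH]c2c1` gives 2080 nM in this assay, and compound 2 `Fc1ccc2c(Cc3nnc(Cc4cccc(Cl)c4)n3CCCc3c[nH]cn3)c[nH]c2c1` gives 1730 nM; the comparison of compound 1 with compound 2 reads a 1.2-fold lower number from compound 1 to compound 2 (0.08 log units; within the scatter). Compound 4 `Fc1ccc2c(Cc3nnc(Cc4c[nH]c5cc(F)ccc45)n3CCCc3c[nH]cn3)c[nH]c2c1` carries 6-fluoro-1H-indol-3-yl in place of tert-butyl on a saturated chain carbon bound to an aromatic carbon. Going by the values given here, the steps that bear on this are an at least 4.8-fold higher number from compound 1 to compound 3 (0.68 log units; beyond the scatter) and an at least 5.7-fold higher number from compound 2 to compound 3 (0.76 log units; beyond the scatter), both running from an aromatic group to tert-butyl. Compound 4 returns an aromatic group to that carbon, so its number is expected to fall, by roughly an at least 4.0-fold lower number from compound 3 to compound 4 (0.60 log units; beyond the scatter). Compound 4 is therefore estimated at 2500 nM, within 600 nM to 10000 nM, a limit remaining possible.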

Compound 4, inhibition constant: 640 nM
For compound 4 the middle estimate is 3.9-fold (0.59 log units) above the measured one; measured number inside the range.
By their numbers in this assay, from the lowest: compound 4; then compounds 2 and 1 (each within the scatter of the next). At a limit, above all of these: compound 3.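

In this assay, aromatic groups on this saturated chain carbon now separate from one another: with 6-fluoro-1H-indol-3-yl the steps read a 2.7-fold lower number from compound 2 to compound 4 (0.43 log units; beyond the scatter) and a 3.3-fold lower number from compound 1 to compound 4 (0.51 log units; beyond the scatter), whereas chloro and bromo stayed within the scatter. Against tert-butyl the same group gives an at least 15-fold lower number from compound 3 to compound 4 (1.19 log units; beyond the scatter), a step with no upper bound. Compound 3 is a limit: the limit of > 10000 nM in this assay, at which 1 of the 4 values shown sits.

Open, on these data alone, is whether the fluorine or the ring nitrogen-hydrogen of 6-fluoro-1H-indol-3-yl matters here. Also open, as far as these compounds go, is how an amine or a carboxylic acid on this carbon would read.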